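The source may hold more compounds than are shown below. What is called first, only, known or untested is meant among the compounds shown, and "the series" means these compounds.

Compound 1 `C#Cc1cccc(Nc2ncnc3sc(NC(=O)/C=C/c4ccccc4)cc23)c1` gives 5050 nM in a functional assay on MDA-MB-231 cells (Homo sapiens) for antiproliferative activity, read by MTT assay, with a stated time of 48 h; on this read-out higher numbers stand for weaker inhibition and lower numbers for stronger inhibition.
Compound 2 `COc1ccc(/C=C/C(=O)Nc2cc3ncnc(Nc4ccc(F)c(Cl)c4)c3s2)cc1` gives 2600 nM in this assay.

Only these two compounds have been measured, and they share one core with a cinnamamide on one side and an anilino group on the other. Among the measured compounds shown here, compound 1 and compound 2 differ in more than one place, so no single step separates them; their two values lie within the usual scatter of each other, and neither can be called the more or less potent of the pair.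

Compound 3 `O=C(/C=C/c1ccccc1)Nc1cc2c(Nc3cc(Cl)cc(Cl)c3)ncnc2s1` has not yet been measured in this assay. It is reached from compound 1 by one change:

3,5-dichlorophenyl in place of 3-ethynylphenyl on a nitrogen on an aromatic ring

Nothing measured here shows how this change acts on the read-out. For the measured compounds named here, with no guiding step, the expected outcome for compound 3 is a step of a 1.2-fold higher number from compound 1 to compound 3 (0.07 log units; within the scatter), not beyond the scatter. Compound 3 is therefore estimated at 6000 nM, with a range from 2500 nM to 15000 nM.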

Compound 3, half-maximal inhibitory concentration: 11500 nM
The estimate for compound 3 lay 1.9-fold (0.28 log units) below the measured number, within the range that was stated.
By their numbers in this assay, from the lowest: compounds 2 and 1 (each within the scatter of the next); then compound 3.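

In this assay, this position gives its first readable step: 3,5-dichlorophenyl in place of 3-ethynylphenyl on a nitrogen on an aromatic ring produces a 2.3-fold higher number from compound 1 to compound 3 (0.36 log units; beyond the scatter), a modest change. Both groups have 8 heavy atoms and one six-membered aromatic ring of carbon only, and neither has a hydrogen-bond donor or acceptor, yet the read-out still moves beyond the scatter, so the group on this nitrogen is not interchangeable even among groups alike in these counts. No measurement available here accounts for the step.

This single pair cannot show whether the loss of the ethynyl group or the arrival of the two chlorines sets the size of the step. As far as these compounds go, how an unsubstituted phenyl or a pyridyl ring on this nitrogen would compare with compound 1 remains open.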